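A few compounds are considered here, and "the series" means these few. Any claim that something is new, unique, unknown or untested is made for them only; others in the source may bear on it.

Measured so far in a functional assay on MCF7 cells (Homo sapiens) for inhibition, read by sulforhodamine B assay (on this read-out higher numbers stand for weaker inhibition and lower numbers for stronger inhibition), each value a limit and not a number:

Compound 1 `O=C1C=C(NC2CCCCC2)C(=O)c2c1nc1n2[C@H]2OC[C@@H](O)[C@H]2OC1`: > 8000 nM
Compound 2 `O=C1C(N2CCC2)=CC(=O)c2c1nc1n2[C@H]2OC[C@@H](O)[C@H]2OC1`: > 16000 nM
Compound 3 `CCOc1ccccc1NC1=CC(=O)c2nc3n(c2C1=O)[C@H]1OC[C@@H](O)[C@H]1OC3`: > 4000 nM

Compound 1 has no numerical position in this assay, and its value of > 8000 nM is a limit. The other two values shown are also limits, so the series offers no measured number as a reference.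

Compound 4 `CCCN(CCC)C1=CC(=O)c2nc3n(c2C1=O)[C@H]1OC[C@@H](O)[C@H]1OC3` is next. The change is dipropylamino in place of cyclohexylamino on a double-bonded ring carbon.

Within the data shown here, the one measured step that bears on this is a step that the two limits leave unreadable from compound 1 to compound 3, where 2-ethoxyphenyl replaces cyclohexyl on an amine nitrogen. Among the measured compounds shown here, it gives no size to carry over, and no measured step covers dipropylamino. No step beyond the scatter is therefore expected in this assay, in either direction, and a further limit is the likeliest result. The expected step is a step that the limit leaves unreadable from compound 1 to compound 4. For compound 4 the estimated value is 10000 nM, with an expected range of 2500 nM to 30000 nM.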

Compound 4, half-maximal inhibitory concentration: > 16000 nM
Compound 4 was reported as a limit; the forecaster's own chance of this, stated with the estimate: 70%; middle value at least 1.6-fold (0.20 log units) from the limit.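

In this assay compound 4 gives > 16000 nM, which is a limit. Among these compounds, compound 1 is also a limit, at > 8000 nM, so no step between compound 1 and compound 4 can be read. The compounds shown leave open whether dipropylamino and cyclohexylamino differ at all in this assay.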